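This account rests on a few compounds, and the source may have more. Where it says the series, first, only, none or still open, it means among the compounds named here.

Compound 1, `COc1ccc(C(=O)CSC(=S)Nc2cc(OC)c(OC)c(OC)c2)cc1`: 16.4 ug/mL
Compound 2, `COc1cc(N2C(=S)SCC2(O)c2ccc(Br)cc2)cc(OC)c1OC`: 15.1 ug/mL
Compound 3, `COc1cc(-n2c(-c3ccc(Br)cc3)csc2=S)cc(OC)c1OC`: 58 ug/mL

Of the compounds shown here, three have so far been tested in a functional assay on MDA-MB-231 cells (Homo sapiens) for cytotoxicity, read by MTT assay, with a stated time of 48 h; on this read-out higher numbers stand for weaker inhibition and lower numbers for stronger inhibition. Compound 1 gives 16.4 ug/mL, compound 2 gives 15.1 ug/mL and compound 3 gives 58 ug/mL. Compound 3 therefore stands highest of the three numbers, which on this read-out means the weakest inhibition; its distance to compound 1 and to compound 2 lies beyond the usual scatter of repeated measurements, so compound 3 is the least active of the three as measured.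

The next compound, compound 4, `COc1cc(-n2c(-c3ccc(-c4ccccc4)cc3)csc2=S)cc(OC)c1OC`, has not been measured yet. It differs from compound 3 in a single place: phenyl in place of bromo on an aromatic carbon. Among the measured compounds no pair shows what this kind of exchange does, so there is nothing to compare the step against. The expectation rests only on compound 3 and on the fact that the rest of the structure is untouched. I expect the step of a 1.5-fold lower number from compound 3 to compound 4 (0.16 log units; within the scatter) to be modest, a slight move toward stronger inhibition that may still fall within the scatter. For compound 4 in this assay I estimate 40 ug/mL, with a plausible range from 14 ug/mL to 110 ug/mL.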

Compound 4, half-maximal inhibitory concentration: > 100 ug/mL
Compound 4: no number, only a limit; the forecaster's own chance of this, stated with the estimate: 15%; middle value at least 2.5-fold (0.39 log units) away from the limit.
By their numbers in this assay, from the lowest: compounds 2 and 1 (each within the scatter of the next); then compound 3. At a limit, above all of these: compound 4.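

In this assay, the exchange of bromo for phenyl on this aromatic carbon, para to a large group, gives an at least 1.7-fold higher number from compound 3 to compound 4 (0.23 log units; that floor lies within the scatter), so this larger group brings no gain in inhibition at this position. Among these compounds, for compound 4 the reading is a limit and not a number: the limit of > 100 ug/mL in this assay, at which 1 of the 4 values shown sits. This is the first information on this position, since no earlier pair of compounds changed only this group, and it shows that adding a whole carbon ring here does not move the result toward stronger inhibition, although the true size of the step remains unknown and its floor lies within the scatter.

The compounds shown leave open whether an amine or a carboxylic acid in place of bromo would give a lower number, which would point to stronger inhibition, or whether this position gives no such gain with any group. They also leave open whether a chlorine atom or a short chain such as ethyl would give a result closer to that of bromo or to that of phenyl.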